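Chloro to methoxy on the pendant ring of compound 2

The source may hold more compounds than are shown below. What is called first, only, known or untested is meant among the compounds shown, and "the series" means these compounds.

Compound 2 `CC(=O)n1cc(/C=C(/C(=O)O)c2ccc(Cl)cc2)c2cc(OCc3ccccc3)ccc21` gives in a functional assay on M14 cells (Homo sapiens) for cytotoxicity, read by MTT assay, with a stated time of 72 h (on this read-out lower numbers stand for stronger inhibition and higher numbers for weaker inhibition), only the limit > 100000 nM, a limit of the method rather than a number; it sits at the limit of > 100000 nM in this assay, at which 1 of the 2 values shown sits. Compound 1 `COc1cc(/C(=C\c2cn(C(C)=O)c3ccc(OCc4ccccc4)cc23)C(=O)O)cc(OC)c1OC` gives 57100 nM in this assay. Within the data shown here, the single measured step, an at least 1.7-fold higher number from compound 1 to compound 2 (0.24 log units; that floor lies within the scatter), points toward weaker inhibition. Compound 3 `COc1ccc(/C(=C\c2cn(C(C)=O)c3ccc(OCc4ccccc4)cc23)C(=O)O)cc1` differs from compound 2 by methoxy in place of chloro on an aromatic carbon. Among the measured compounds shown here, no measured step covers this exchange, so no shift beyond the scatter is expected. Compound 3 is thus expected near the limit, at 80000 nM with a range from 30000 nM to 200000 nM, a step of an at least 1.2-fold lower number from compound 2 to compound 3 (0.09 log units; that floor lies within the scatter) expected to stay within the scatter.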

Compound 3, half-maximal inhibitory concentration: > 100000 nM
Compound 3: a limit, no number (the forecaster's own chance of this, stated with the estimate: 50%); middle value at least 1.2-fold (0.09 log units) from the limit.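

In this assay, methoxy in place of chloro, para to a large group, gives a second limit rather than a number: the limit of > 100000 nM in this assay, at which 2 of the 3 values shown sit.
The step between compound 2 and compound 3 cannot be read, as both values are limits. The one readable step, an at least 1.7-fold higher number from compound 1 to compound 3 (0.24 log units; that floor lies within the scatter), gives only a floor, and among these compounds only compound 1, with its 3,4,5-trimethoxyphenyl, has a number.

Going by these compounds, whether a single methoxy differs at all from chloro here stays open. So does whether an amine or a hydroxyl at this position would give a number.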